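The source may report more compounds than this note shows. Statements on the series, on what has been measured and on what is new or still open speak of the compounds shown alone.

Measured so far in a functional assay on the whole organism (strain Wistar) for inhibition, with Rattus norvegicus as the target, read by paw edema, with a stated time of 24 h, at a dose of 100 mg/kg; a lower number here means less inhibition, a higher number more inhibition at the dose given (going by the name of the read-out):
compound 1, `COc1cc2c(cc1OC)C(CC(=O)Nc1ccccc1)CC2`, gives 30%;
compound 2, `COc1cc2c(cc1OC)C(CC(=O)Nc1ccc(Br)cc1)CC2`, gives 66.7%;
compound 3, `COc1ccccc1NC(=O)CC1CCc2cc(OC)c(OC)cc21`, gives 30%.

Compound 3 stands level with compound 1, the pair together forming the lowest two numbers of the three, with no change at the digits printed from compound 1 to compound 3 (within the scatter). Compound 2 sits well above it, seen in a number 36.7 percentage points lower from compound 2 to compound 3 (beyond the scatter).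

The next compound, compound 4, is `COc1cc2c(cc1OC)C(CC(=O)Nc1ccccn1)CC2`. It changes the group on the amide nitrogen of compound 3: pyridin-2-yl in place of 2-methoxyphenyl on an amide-type nitrogen. Among the compounds with values here, two measured steps touch that same place: no change at the digits printed from compound 1 to compound 3 (within the scatter) was nothing beyond the scatter, while a number 36.7 percentage points lower from compound 2 to compound 3 (beyond the scatter) was large. Within the data shown here, no measured step puts a nitrogen into this ring, so no firm direction can be read. Compound 4 is therefore expected near compound 3, with a number 5 percentage points higher from compound 3 to compound 4 (within the scatter), estimated at 35%, ranging from 15% to 60%.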

Compound 4, a percentage reported as inhibition, in the whole organism at one dose (the size of the read-out at that dose, not a potency): 33.3%
Estimate against measurement, compound 4: 1.7 percentage points above, within the range that was stated.
By their numbers in this assay, from the lowest: compounds 1, 3 and 4 (each within the scatter of the next); then compound 2.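

In this assay, a ring nitrogen in the group on the amide-type nitrogen is new, and it leaves the number about where it was: a number 3.3 percentage points higher from compound 1 to compound 4 (within the scatter) and a number 3.3 percentage points higher from compound 3 to compound 4 (within the scatter) are both within the scatter. The 4-bromophenyl group still stands apart, with a number 33.4 percentage points lower from compound 2 to compound 4 (beyond the scatter) beyond the scatter. No measured evidence bears on these results.

As far as these compounds go, whether a pyridin-2-yl group carrying bromo would reach the level of compound 2 remains open. So does the outcome for a phenyl group carrying an amine or a carboxylic acid in place of the bromo.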